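This account rests on a few compounds, and the source may have more. Where it says the series, first, only, none or still open, it means among the compounds named here.

Working notes on the series. In a functional assay on B16-F0 cells (Mus musculus) for inhibition, read by CCK-8 assay, with a stated time of 48 h (a lower number here means a stronger inhibitor, a higher number a weaker inhibitor), compound 1 `C=Cc1ccc(-c2cc3nccc(-c4cc(OC)c(OC)c(OC)c4)n3n2)cc1` gives 788 nM and compound 2 `COc1cc(-c2ccnc3cc(-c4cccc(C)c4)nn23)cc(OC)c1OC` gives 2220 nM, so compound 2 holds the higher of the two numbers and is the weaker inhibitor so far. Within the data shown here, only one measured step exists: a 2.8-fold higher number from compound 1 to compound 2 (0.45 log units; beyond the scatter), a modest change beyond the scatter, made by putting 3-methylphenyl in place of 4-vinylphenyl on an aromatic carbon.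

The next compound is compound 3 `COc1cc(-c2ccnc3cc(-c4ccc(C(C)=O)cc4)nn23)cc(OC)c1OC`, which carries 4-acetylphenyl in place of the 3-methylphenyl of compound 2, on the same aromatic carbon of a five-membered aromatic ring with 2 nitrogen: 4-acetylphenyl in place of 3-methylphenyl on an aromatic carbon. The new group shares the 4-substituted phenyl form of compound 1 but is not the same group, and a single step is thin support. Read in reverse, a 2.8-fold higher number from compound 1 to compound 2 (0.45 log units; beyond the scatter) suggests a partial return toward a lower number in this assay, smaller than that measured step. The estimate means a 1.6-fold lower number from compound 2 to compound 3 (0.20 log units; within the scatter), an expected move that is small and may stay within the scatter. For compound 3 the expected value is 1400 nM, with an estimated range of 500 nM to 4000 nM.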

Compound 3, half-maximal inhibitory concentration: 3930 nM
For compound 3 the middle estimate is 2.8-fold (0.45 log units) below the measured one, and the stated range covers the measured number.
By their numbers in this assay, from the lowest: compound 1; then compounds 2 and 3 (each within the scatter of the next).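

In this assay, putting 4-acetylphenyl in place of 3-methylphenyl on this aromatic carbon gives a 1.8-fold higher number from compound 2 to compound 3 (0.25 log units; within the scatter) and so does not separate the two groups, even though the new group brings more heavy atoms and one hydrogen-bond acceptor. The series now also has a comparison that keeps the 4-substituted phenyl and changes only its substituent: acetyl in place of vinyl gives a 5.0-fold higher number from compound 1 to compound 3 (0.70 log units; beyond the scatter) and is the clearer result. The 4-substituted phenyl form alone therefore does not go with the lower number, and the vinyl group of compound 1 is the only substituent shown here that stands apart from the others, though no measurement at hand explains this.

The compounds shown do not separate the place of a substituent on the phenyl ring from its identity, and 3-acetylphenyl or 3-vinylphenyl would test that directly. Going by these compounds, it also remains open how 4-ethylphenyl, an amine or a carboxylic acid at the same place on the phenyl ring would compare with vinyl and acetyl.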